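The source may report more compounds than this note shows. Statements on the series, on what has been measured and on what is new or still open speak of the compounds shown alone.

Three compounds share one core and differ only in the group on a saturated chain carbon bound to an amide-type nitrogen. Compound 1 `O=C(NCc1ccccc1Br)N1C(=O)c2ccccc2S1(=O)=O`, compound 2 `O=C(NCc1ccccc1C(F)(F)F)N1C(=O)c2ccccc2S1(=O)=O` and compound 3 `O=C(NCc1cccc(Br)c1)N1C(=O)c2ccccc2S1(=O)=O` were each tested in a physicochemical assay for pharmacokinetics; on this read-out higher numbers stand for a longer-lived compound and lower numbers for a shorter-lived compound. Compound 1 reached a limit of the assay and gave > 166 h. Compound 2 likewise gave only a limit, > 166 h. Compound 3 also stands at a limit with > 166 h. Because all three values sit at the limit of > 166 h in this assay, at which 3 of the 3 values shown sit, the steps a step that the two limits leave unreadable from compound 1 to compound 2 and a step that the two limits leave unreadable from compound 1 to compound 3 cannot be read. Compound 4 `Cc1ccccc1CNC(=O)N1C(=O)c2ccccc2S1(=O)=O` has not yet been measured. It differs from compound 3 in one place: 2-methylphenyl in place of 3-bromophenyl on a saturated chain carbon bound to an amide-type nitrogen. Going by the values given here, no measured step bears on this change in a readable way, and no measured compound carries a 2-methylphenyl. The expectation for compound 4 therefore rests only on the three limits, and the step that the limit leaves unreadable from compound 3 to compound 4 is expected to stay within the usual scatter. Compound 4 is estimated to give 200 h in this assay, between 80 h and 500 h.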

Compound 4, half-life: > 166 h
Compound 4: only a limit was reported; the forecaster's own chance of this, stated with the estimate: 70%; the middle value does not contradict the limit.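

Compound 4 also gives only a limit in this assay, so its steps from compound 1, compound 2 and compound 3 cannot be read: the limit of > 166 h in this assay, at which 4 of the 4 values shown sit. The compounds shown leave open how long each one actually lasts, and whether swapping these groups changes the half-life at all.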